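Working notes: from compound 2 to compound 4

The source may report more compounds than this note shows. Statements on the series, on what has been measured and on what is new or still open speak of the compounds shown alone.

Three compounds of the series have been measured in a functional assay on HeLa cells (Homo sapiens) for antiproliferative activity, read by CCK-8 assay, with a stated time of 72 h, tested at 8 uM; on this read-out higher numbers stand for a stronger effect at the one concentration tested and lower numbers for a weaker effect:

compound 1 `Nc1ccccc1NC(=O)c1ccc(CSC(=S)N2CCN(c3ccccc3)CC2)cc1` gives 73.1%
compound 2 `Nc1ccccc1NC(=O)c1ccc(CSC(=S)N2CCc3ccccc32)cc1` gives 67%
compound 3 `COc1ccc(N2CCN(C(=S)SCc3ccc(C(=O)Nc4ccccc4N)cc3)CC2)cc1` gives 52.3%

Compound 2 sits within the scatter of compound 1, while the gap to compound 3 is beyond the scatter, compound 3 giving the lower number. Among the compounds with values here, the one step between compounds that differ in a single place, a number 20.8 percentage points lower from compound 1 to compound 3 (beyond the scatter), concerns a substituent on an aromatic carbon of the ring attached to the amine nitrogen and is unrelated to the change now at hand.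

Compound 4 `Nc1ccccc1NC(=O)c1ccc(CSC(=S)N2CCCc3ccccc32)cc1` differs from compound 2 in one place: 1,2,3,4-tetrahydroquinolin-1-yl in place of 2,3-dihydro-1H-indol-1-yl on a thiocarbonyl carbon. Within the data shown here, no measured pair changes the size of this non-aromatic ring, so nothing directly bears on the step. Among the measured compounds shown here, the nearest precedent is that exchanging one nitrogen-linked group for another of similar shape, as between compound 1 and compound 2, leaves the number within the scatter. A step of no more than the scatter is therefore expected, in either direction.

Compound 4 is estimated to give 66% in this assay, within 52% to 78%, which amounts to an expected step of a number 1 percentage points lower from compound 2 to compound 4 (within the scatter).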

Compound 4, a percentage reported as inhibition, at one concentration (the size of the read-out at that concentration, not a potency): 35.7%
For compound 4 the middle estimate is 30.3 percentage points above the measured one; the whole stated range lies above it.
By their numbers in this assay, from the lowest: compound 4; then compound 3; then compounds 2 and 1 (each within the scatter of the next).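

In this assay, the change from 2,3-dihydro-1H-indol-1-yl to 1,2,3,4-tetrahydroquinolin-1-yl on a thiocarbonyl carbon gives a number 31.3 percentage points lower from compound 2 to compound 4 (beyond the scatter), the largest step yet seen in the series. The earlier single-place step concerned only a methoxy on an aromatic carbon, whereas this pair shows that the read-out also responds to the size of the non-aromatic ring, five-membered in compound 2 and six-membered in compound 4, with the aromatic ring of carbon only and the hydrogen-bond counts of the group unchanged. Nothing available accounts for this step, and its origin remains unexplained.

The compounds shown leave open whether a seven-membered non-aromatic ring in the same position would continue this trend or whether the five-membered ring is a narrow optimum, and how a methyl on the non-aromatic ring of the 1,2,3,4-tetrahydroquinolin-1-yl group would read. As far as these compounds go, because the read-out comes from one concentration and is not a potency, it also remains open whether the gap would persist across a full concentration range.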